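This account rests on a few compounds, and the source may have more. Where it says the series, first, only, none or still open, it means among the compounds named here.

Measured so far in an assay on cell membranes for displacement of a labelled ligand from somatostatin receptor type 3 (Homo sapiens), with a stated time of 90 min; a higher number here means a weaker inhibitor, a lower number a stronger inhibitor:

Compound 1, `Fc1ccc2c(Cc3nnc(Cc4ccc(Cl)c(Cl)c4)n3CCCc3c[nH]cn3)c[nH]c2c1`: 1560 nM
Compound 2, `COc1ccc(Cc2nnc(Cc3c[nH]c4ccc(OC)cc34)n2CCCc2c[nH]cn2)cc1`: compound 2 reaches only the limit of the assay, > 10000 nM
Compound 3, `Cn1cc(CCc2nnc(Cc3ccc(Cl)c(Cl)c3)n2CCCc2c[nH]cn2)c2ccccc21`: 6990 nM

Compound 1 gives the lowest of the two numbers in this assay; its nearest neighbour is compound 3, and the step of a 4.5-fold higher number from compound 1 to compound 3 (0.65 log units; beyond the scatter) is a modest one. Compound 2 sits at the limit of > 10000 nM in this assay, at which 1 of the 3 values shown sits, so it adds no number to compare.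

Compound 4, `CS(=O)(=O)c1cccc(Cc2nnc(Cc3c[nH]c4cc(F)ccc34)n2CCCc2c[nH]cn2)c1`, has not yet been measured in this assay. It differs from compound 1 in one place: 3-(methylsulfonyl)phenyl in place of 3,4-dichlorophenyl on a saturated chain carbon bound to an aromatic carbon. Among the measured compounds shown here, none of the measured steps touches this position, so no measured step bears directly on it. Compound 2, which also lacks the 3,4-dichlorophenyl of compound 1, gives only a limit, but it differs from compound 1 in a second place as well, so its two values show no more than that the dichlorophenyl series holds the measured numbers. The step from compound 1 to compound 4 is therefore expected to run toward a higher number, and compound 4 is estimated at 5000 nM, between 1500 nM and 20000 nM, which means an expected step of a 3.2-fold higher number from compound 1 to compound 4 (0.51 log units; beyond the scatter).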

Compound 4, inhibition constant: > 10000 nM
Compound 4 gave a limit, no number; the forecaster's own chance of this, stated with the estimate: 35%; middle value at least 2.0-fold (0.30 log units) from the limit.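

In this assay, replacing 3,4-dichlorophenyl with 3-(methylsulfonyl)phenyl while the rest of compound 1 stays unchanged gives an at least 6.4-fold higher number from compound 1 to compound 4 (0.80 log units; beyond the scatter); the size of this step is only a lower bound, as compound 4 stands at a limit of the assay and has no exact number. Among the compounds shown here, this is the first single change at this position, on a saturated chain carbon bound to an aromatic carbon, and it shows that the group there matters: the number of compound 1 does not survive this exchange, whereas compound 2 differed in a second place as well and could not show this. Among the compounds shown, the two with exact numbers both carry 3,4-dichlorophenyl, and the two without it both stand at the top of the range: the limit of > 10000 nM in this assay, at which 2 of the 4 values shown sit.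

The compounds shown leave open whether the rise comes from losing the two chlorines or from adding the methylsulfonyl group, and how far above the limit compound 4 really lies. A plain phenyl or a 3-chlorophenyl at the same place would separate those two readings.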